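The source may hold more compounds than are shown below. What is called first, only, known or untested is meant among the compounds shown, and "the series" means these compounds.

compound 1 `Fc1ccc(NC(=S)Nc2cccc(C(F)(F)F)c2)cc1` gives 41000 nM
compound 2 `CCOC(=O)c1ccc(NC(=S)Nc2cccc(C(F)(F)F)c2)cc1` gives 64000 nM

Among the measured compounds shown here, in an ADME assay on MDBK cells (Bos taurus) for cytotoxicity, read by MTT assay, with a stated time of 96 h (on this read-out higher numbers stand for lower toxicity in this test and lower numbers for higher toxicity in this test), compound 1 stands level with compound 2, the only other measured compound, and the single measured step, a 1.6-fold higher number from compound 1 to compound 2 (0.19 log units; within the scatter), lies within the scatter. Compound 3 `FC(F)(F)c1cccc(NC(=S)NCc2ccco2)c1` carries (furan-2-yl)methyl in place of 4-fluorophenyl on an amide-type nitrogen. The measured step only exchanged a group on an aromatic carbon, so it bears on this larger change loosely, and no shift beyond the scatter is expected. The estimate is a 1.2-fold higher number from compound 1 to compound 3 (0.09 log units; within the scatter). Compound 3 is expected at 50000 nM, within a range of 22000 nM to 100000 nM.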

Compound 3, half-maximal cytotoxic concentration: > 100000 nM
Compound 3: a limit, no number; the forecaster's own chance of this, stated with the estimate: 20%; at least 2.0-fold (0.30 log units) between middle value and limit.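

In this assay, (furan-2-yl)methyl in place of 4-fluorophenyl on an amide-type nitrogen gives an at least 2.4-fold higher number from compound 1 to compound 3 (0.38 log units; beyond the scatter), whereas the exchange on an aromatic carbon gave a 1.6-fold higher number from compound 1 to compound 2 (0.19 log units; within the scatter). Compound 3 gives > 100000 nM, which is a limit of the assay and not a number. The step therefore sets only a floor, and its full size is unknown: the limit of > 100000 nM in this assay, at which 1 of the 3 values shown sits.

From the compounds shown here alone, whether the furan ring or the methyl link matters more remains open. So does how a benzyl group, a longer alkyl chain or an amine-bearing chain on this nitrogen would read.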